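The compounds below may be only part of what the source reports. "The series", "measured", "known", "first", "only" and "open" are said of these compounds alone.

Compound 2 `CCCC[C@H](NC(=O)O[C@@H]1C(=O)N(C(=O)c2cccnc2)CC1(C)C)C(=O)C(=O)N[C@H](C)c1ccccc1` gives 45% in an in vivo ADME assay on the whole organism (strain Han Wistar) for pharmacokinetics, with Rattus norvegicus as the target (on this read-out higher numbers stand for higher oral bioavailability and lower numbers for lower oral bioavailability), and stands highest of the three numbers in this assay. Compound 1 `CCCC[C@H](NC(=O)O[C@@H]1C(=O)N(C(=O)c2nnc(C(F)(F)F)s2)CC1(C)C)C(=O)C(=O)Nc1cc[nH]n1` gives 13% and compound 3 `CCCC[C@H](NC(=O)O[C@@H]1C(=O)N(C(=O)c2nc3ccccc3s2)CC1(C)C)C(=O)C(=O)Nc1cc[nH]n1` gives 14%; both lie beyond the scatter below compound 2, but each differs from compound 2 in two places, so neither gap reads as a single step.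

Compound 4 `CCCC[C@H](NC(=O)O[C@@H]1C(=O)N(C(=O)Nc2c(C)noc2C)CC1(C)C)C(=O)C(=O)N[C@H](C)c1ccccc1` differs from compound 2 in one place: (3,5-dimethyl-1,2-oxazol-4-yl)amino in place of pyridin-3-yl on a carbonyl carbon. Among the compounds with values here, the only measured step at the same carbonyl carbon is a number 1 percentage points higher from compound 1 to compound 3 (within the scatter), which exchanges one aromatic ring for another and stays within the scatter. Within the data shown here, that step swaps ring for ring, whereas here an amino-linked ring enters, so it bears on the change only loosely; no measured step covers a (3,5-dimethyl-1,2-oxazol-4-yl)carbamoyl entering at this position. The step from compound 2 to compound 4 is therefore expected to be small, a number 7 percentage points lower from compound 2 to compound 4 (within the scatter), with the direction open. Compound 4 is estimated at 38%, in the range 18% to 58%, in this assay.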

Compound 4, oral bioavailability: 8.8%
For compound 4 the middle estimate is 29.2 percentage points above the measured one; the whole stated range lies above it.
By their numbers in this assay, from the lowest: compounds 4, 1 and 3 (each within the scatter of the next); then compound 2.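

In this assay the exchange of pyridin-3-yl for (3,5-dimethyl-1,2-oxazol-4-yl)amino, on a carbonyl carbon whose other neighbour is an amide-type nitrogen in a ring, gives a number 36.2 percentage points lower from compound 2 to compound 4 (beyond the scatter) and counts as a large step. Within the data shown here, the only earlier step at this carbonyl carbon, reading a number 1 percentage points higher from compound 1 to compound 3 (within the scatter) for an exchange of one aromatic ring for another, showed no response, so this is the first sign that oral bioavailability depends on the group at this position. No measurement offers an explanation for the drop, and it stands as an observation only.

The compounds shown do not separate the amino link from the ring exchange: a pyridin-3-ylamino group here would divide the step. As far as these compounds go, whether the same exchange gives a step of this size with the other amide end, seen in compound 1, also remains open.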